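A few compounds are considered here, and "the series" means these few. Any claim that something is new, unique, unknown or untested is made for them only; others in the source may bear on it.

Measured so far:
compound 1, `COc1ccc(-c2ssc(=S)c2-c2cc(OC)c(OC)c(OC)c2)cc1O`: 271 nM
compound 2, `COc1ccc(-c2ssc(=S)c2-c2cc(OC)c(OC)c(OC)c2)cc1N`: 444 nM
compound 3, `CO/N=c1/ssc(-c2ccc(OC)c(O)c2)c1-c1cc(OC)c(OC)c(OC)c1`: 10000 nM

All three were tested in a functional assay on SGC-7901 cells (Homo sapiens) for antiproliferative activity, read by MTT assay, with a stated time of 72 h; a higher number here means a weaker inhibitor, a lower number a stronger inhibitor. Compound 1 and compound 2 share a core and differ only in one place: amino in place of hydroxy on an aromatic carbon. That change gave a 1.6-fold higher number from compound 1 to compound 2 (0.21 log units; within the scatter), so the two numbers cannot be told apart with confidence. Compound 3 carries a different core; how the core of compound 3 differs from the core of compound 1 is not broken down here. In this assay compound 3 gives the highest number of the three, and its distance to both compound 1 and compound 2 lies beyond the scatter, so compound 3 is the weakest inhibitor of the set.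

Compound 4, `CO/N=c1/ssc(-c2ccc(OC)c(N)c2)c1-c1cc(OC)c(OC)c(OC)c1`, is not yet measured. It relates to compound 3 exactly as compound 2 relates to compound 1: amino in place of hydroxy on an aromatic carbon. The place described for this change is the same, word for word, as for the change from compound 1 to compound 2, so it is the same change, made on the other core.

Going by the values given here, the only guide to its effect is the one earlier instance. Because that instance gave a 1.6-fold higher number from compound 1 to compound 2 (0.21 log units; within the scatter), the expectation is that compound 4 will stay close to compound 3, with a step of about a 1.2-fold higher number from compound 3 to compound 4 (0.08 log units; within the scatter) expected. Compound 4 is therefore estimated at 12000 nM, with a range from 5000 nM to 30000 nM. The transfer of a single observed step to a different core is the main uncertainty, and a reading at the upper edge of the assay is possible.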

Compound 4, half-maximal inhibitory concentration: > 100000 nM
Compound 4: a limit, no number; the forecaster's own chance of this, stated with the estimate: 30%; at least 8.3-fold (0.92 log units) between middle value and limit.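

In this assay compound 4 gives > 100000 nM, which is a limit of the assay and not a number. Amino in place of hydroxy gives an at least 10-fold higher number from compound 3 to compound 4 (1.00 log units; beyond the scatter), so on these two cores the change does not carry over as a constant step: the same change on two cores in this assay, a 1.6-fold higher number (0.21 log units; within the scatter) from compound 1 to compound 2 and an at least 10-fold higher number (1.00 log units; beyond the scatter) from compound 3 to compound 4, at least 6.1-fold (0.78 log units) apart, beyond the scatter of two such steps

This does not fix the true size of the step on the core of compound 3, where only a lower bound is available, and two cores give neither a rule for other cores nor a reason for the difference.

Still open, as far as these compounds go, is how other groups in place of the hydroxy, such as fluoro, methylamino or an acetamide, would read on each of the two cores, and whether any of them would stay close to the hydroxy compound on both. Also open, from the compounds shown here alone, is whether replacing the methoxy on the exocyclic nitrogen of compound 3 and compound 4 with a free hydroxy, an ethoxy or a benzyloxy would alter the readings or the gap between the two cores.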